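Limit-bound cytotoxicity: from methyl to trifluoromethyl

The source may hold more compounds than are shown below. What is called first, only, known or untested is meant among the compounds shown, and "the series" means these compounds.

Compound 1 `CC(=O)Nc1ccc2oc(-c3ccnc(C(=O)N4CCN(C(c5ccc(F)cc5)c5nnn(C)n5)CC4)c3)nc2c1`: > 50000 nM
Compound 2 `CC(=O)Nc1ccc2oc(-c3ccnc(C(=O)N4CCN(C(c5ccc(C)cc5)c5nnn(C)n5)CC4)c3)nc2c1`: > 50000 nM

In an ADME assay on MDCK cells (Canis lupus familiaris) for cytotoxicity (a higher number here means that more compound is tolerated, a lower number that less compound is tolerated), compound 2 gives > 50000 nM, which is a limit of the assay and not a number. Compound 1 gives > 50000 nM, which is a limit as well. So compound 2 has no exact position on the scale, and neither compound offers a number to compare: the limit of > 50000 nM in this assay, at which 2 of the 2 values shown sit.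

The next compound to be tested is compound 3 `CC(=O)Nc1ccc2oc(-c3ccnc(C(=O)N4CCN(C(c5ccc(C(F)(F)F)cc5)c5nnn(C)n5)CC4)c3)nc2c1`. It carries trifluoromethyl in place of methyl on an aromatic carbon, on the same ring that changes between the two measured compounds: trifluoromethyl in place of methyl on an aromatic carbon.

Among the measured compounds shown here, only one measured step bears on this change: a step that the two limits leave unreadable from compound 1 to compound 2. It gives no size or direction to carry over. Still, both measured compounds sit at the same limit, so no step beyond the usual scatter is expected, and compound 3 will probably be reported as a limit too. The expected size of the change is a number no higher from compound 2 to compound 3 (the limit leaves the size open). For compound 3 the estimated value is 50000 nM, with an expected range from 25000 nM to 100000 nM.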

Compound 3, half-maximal cytotoxic concentration: > 50000 nM
Compound 3: a limit, no number; the forecaster's own chance of this, stated with the estimate: 85%; the middle value lies on the limit itself.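

No step among compound 1, compound 2 and compound 3 can be read, because each gives a limit of the assay and not a number: the limit of > 50000 nM in this assay, at which 3 of the 3 values shown sit.

The compounds shown leave open the actual tolerated concentration of each compound in this assay, and whether fluoro, methyl or trifluoromethyl on the aromatic carbon makes any difference to it.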